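Swapping Chlorine for Methoxy on the Shared Core

This account rests on a few compounds, and the source may have more. Where it says the series, first, only, none or still open, it means among the compounds named here.

Within the data shown here, compound 1 `OCC#CCSc1cnc2ccccc2c1Cl` gives 6.2 ug/mL in a functional assay on SW707 cells (Homo sapiens) for cytotoxicity, read by sulforhodamine B assay, with a stated time of 72 h (on this read-out lower numbers stand for stronger inhibition and higher numbers for weaker inhibition), the lowest of the two numbers measured so far. Among the measured compounds shown here, compound 2 `OCC#CCSc1cnc2ccccc2c1[Se]CC#CCO` gives 26.6 ug/mL, and the step of a 4.3-fold higher number from compound 1 to compound 2 (0.63 log units; beyond the scatter) is the only change recorded at that position. Compound 3 `COc1c(SCC#CCO)cnc2ccccc12` differs from compound 1 by methoxy in place of chloro on an aromatic carbon. That recorded step concerns a far larger group than methoxy, so it bears only loosely on this change; a small weakening or none beyond the scatter is expected, a 1.5-fold higher number from compound 1 to compound 3 (0.16 log units; within the scatter). Compound 3 is therefore estimated at 9 ug/mL, within 4 ug/mL to 22 ug/mL.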

Compound 3, concentration for 50% inhibition: 67.4 ug/mL
Compound 3: the middle estimate sits 7.5-fold (0.87 log units) below what was measured; measured number above the stated range.
By their numbers in this assay, from the lowest: compound 1; then compound 2; then compound 3.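

In this assay methoxy in place of chloro gives an 11-fold higher number from compound 1 to compound 3 (1.04 log units; beyond the scatter) and so shows that even a swap of small groups on this aromatic carbon can change the number greatly. The order does not follow group size here, as replacing the group of 6 heavy atoms with the smaller methoxy gives a 2.5-fold higher number from compound 2 to compound 3 (0.40 log units; beyond the scatter) while chloro, the smallest group, has the lowest number. No measurement on hand explains this order. Going by these compounds, whether fluorine, an amine or a longer chain such as ethoxy would stay near compound 1 or near compound 3 remains open.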